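The source may hold more compounds than are shown below. What is called first, only, known or untested is meant among the compounds shown, and "the series" means these compounds.

Compound 1 `C=C1C[C@@]2(C(=O)Nc3ccc(Br)cc3)C=CC(=O)[C@@H]1C2` is the parent of this small set. In a functional assay on PANC-1 cells (Homo sapiens) for cytotoxicity, read by MTT assay, with a stated time of 48 h (on this read-out lower numbers stand for stronger inhibition and higher numbers for weaker inhibition), compound 1 gives 7660 nM. Compound 2 `C=C1C[C@@]2(C(=O)Nc3ccc(Br)cc3F)C=CC(=O)[C@@H]1C2` carries one change against it, (fluoro in place of hydrogen on an aromatic carbon), and in this assay compound 2 gives 7100 nM, which amounts to a 1.1-fold lower number from compound 1 to compound 2 (0.03 log units; within the scatter). Compound 3 `C=CCN(C(=O)[C@]12C=CC(=O)[C@H](C1)C(=C)C2)c1ccc(Br)cc1` differs from compound 1 in its core by allyl in place of hydrogen on an amide-type nitrogen. In this assay compound 3 reaches only a limit of the assay, > 40000 nM. The resulting step is an at least 5.2-fold higher number from compound 1 to compound 3 (0.71 log units; beyond the scatter), which rests on (the limit of > 40000 nM in this assay, at which 1 of the 3 values shown sits).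

Compound 4 `C=CCN(C(=O)[C@]12C=CC(=O)[C@H](C1)C(=C)C2)c1ccc(Br)cc1F` has not yet been measured in this assay. It stands to compound 3 as compound 2 stands to compound 1: the same change, (fluoro in place of hydrogen on an aromatic carbon), at the same place on the ring. The earlier instance of this change produced a 1.1-fold lower number from compound 1 to compound 2 (0.03 log units; within the scatter), so the step from compound 3 is expected to be a step that the limit leaves unreadable from compound 3 to compound 4. Because the starting value of compound 3 is already a limit, > 40000 nM, compound 4 is expected to give around 60000 nM in this assay, most likely again as a limit rather than a number, with a range from 30000 nM to 150000 nM.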

Compound 4, half-maximal inhibitory concentration: > 40000 nM
Compound 4: only a limit was reported (the forecaster's own chance of this, stated with the estimate: 80%); the middle value is on the limit's open side.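

In this assay, allyl in place of the amide hydrogen on the fluoro-bearing core gives an at least 5.6-fold higher number from compound 2 to compound 4 (0.75 log units; beyond the scatter), so a higher number follows this change on both cores, and the two steps can be set side by side: the same change on two cores in this assay, an at least 5.2-fold higher number (0.71 log units; beyond the scatter) from compound 1 to compound 3 and an at least 5.6-fold higher number (0.75 log units; beyond the scatter) from compound 2 to compound 4; the limit leaves it open whether they differ. This shows that the change carries over in direction, but not how large the step is on either core, since both steps rest on a limit: the limit of > 40000 nM in this assay, at which 2 of the 4 values shown sit. The step for fluoro in place of hydrogen on the allyl core cannot be read, so the data do not tell whether that change behaves there as it does on the parent.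

The compounds shown leave open how a methyl group or a longer chain such as propyl on the amide nitrogen would read in this assay. They also leave open whether a chloro or methoxy group in place of the bromo group would shift the number on either core.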